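The source may hold more compounds than are shown below. What is called first, only, known or untested is meant among the compounds shown, and "the series" means these compounds.

Measured compounds:
- compound 1, `Cc1cc(S(=O)(=O)/N=C(\N)N/N=C/C#Cc2ccccc2)c(SCc2ccccc2C)cc1Cl`: 17000 nM in an ADME assay on HaCaT cells (Homo sapiens) for cytotoxicity, read by MTT assay, with a stated time of 72 h; a lower number here means a stronger inhibitor, a higher number a weaker inhibitor
- compound 2, `C/C(C#Cc1ccccc1)=N\N/C(N)=N/S(=O)(=O)c1cc(C)c(Cl)cc1SCc1ccccc1C`: "not determined" (no result reported) in this assay

For the measured compounds named here, compound 1 is the only compound with a number in this assay, since compound 2 has no result there, so nothing can yet be said about how a change in structure shifts this read-out. Compound 3, `Cc1cc(S(=O)(=O)/N=C(\N)N/N=C/C#Cc2ccccc2)c(SCc2cccc3ccccc23)cc1Cl`, differs from compound 1 in one place: naphthalen-1-yl in place of 2-methylphenyl on a saturated chain carbon bound to a sulfur. Going by the values given here, with no measured pair to lean on, the expected step is small, and in a 1.4-fold lower number from compound 1 to compound 3 (0.15 log units; within the scatter) compound 3 is estimated to come out close to compound 1, with perhaps a slight lean toward a lower number, a shift that stays within the usual scatter of repeated runs. Compound 3 is therefore expected to give about 12000 nM in this assay, within a range from 5000 nM to 30000 nM.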

Compound 3, half-maximal inhibitory concentration: 5000 nM
Estimate against measurement, compound 3: 2.4-fold (0.38 log units) above; the range from low to high includes it.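

In this assay, the change from 2-methylphenyl to naphthalen-1-yl on a saturated chain carbon bound to a sulfur gives a 3.4-fold lower number from compound 1 to compound 3 (0.53 log units; beyond the scatter) and this step lies beyond the scatter of repeated measurements. For the compounds shown here, it is the first readable comparison and shows that the read-out responds to a change at this position, with a lower number when a group with two six-membered aromatic rings replaces a group with one. Nothing shown explains why the number falls.

A single step cannot separate the effect of adding the second ring from that of losing the methyl group on the original ring. It also leaves open how this read-out would respond to other groups here, such as an unsubstituted phenyl ring, a longer chain before the ring, or a carboxylic acid on the ring.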